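Adding a methyl to compound 2

The source may report more compounds than this note shows. Statements on the series, on what has been measured and on what is new or still open speak of the compounds shown alone.

In a functional assay on HeLa cells (Homo sapiens) for inhibition, read by sulforhodamine B assay, with a stated time of 74 h (a lower number here means a stronger inhibitor, a higher number a weaker inhibitor), compound 1 `Cc1ccc(S(=O)(=O)N2C(=O)C(C)OC23C=CC(=O)C=C3)cc1` gives > 10000 nM as a limit and not as a number. Among the compounds with values here, compound 2 `O=C1C=CC2(C=C1)OCC(=O)N2S(=O)(=O)c1cccs1` stands at 3420 nM as the only actual number so far. Compound 3 `CC1OC2(C=CC(=O)C=C2)N(S(=O)(=O)c2cccs2)C1=O` differs from compound 2 by methyl in place of hydrogen on a saturated ring carbon and carries methyl in place of hydrogen on a saturated ring carbon. Within the data shown here, no measured pair isolates this change, and in this assay no step beyond the scatter is expected: the estimated step of a 1.3-fold higher number from compound 2 to compound 3 (0.12 log units; within the scatter) leans slightly toward weaker inhibition. Compound 3 is estimated at 4500 nM with a range from 1800 nM to 9000 nM expected.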

Compound 3, half-maximal inhibitory concentration: 270 nM
For compound 3 the middle estimate is 17-fold (1.22 log units) above the measured one; the measured number lies below the stated range.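

In this assay, methyl in place of hydrogen on the saturated ring carbon next to the ring oxygen gives a 13-fold lower number from compound 2 to compound 3 (1.10 log units; beyond the scatter), so this position responds strongly to a single added carbon. With that methyl present in both compounds, thiophen-2-yl in place of 4-methylphenyl on the sulfonyl sulfur gives an at least 37-fold lower number from compound 1 to compound 3 (1.56 log units; beyond the scatter), so the methyl alone does not secure the gain. Compound 1 stands at a limit and not at a number: the limit of > 10000 nM in this assay, at which 1 of the 3 values shown sits.

Open, on these data alone, is whether a longer chain such as ethyl, or a hydroxymethyl or an amine, on this carbon keeps the gain. Also open, as far as these compounds go, is whether the methyl step holds with 4-methylphenyl on the sulfonyl sulfur.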